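The source may hold more compounds than are shown below. What is called first, only, known or untested is meant among the compounds shown, and "the series" means these compounds.

Three compounds have so far been tested in a functional assay on SF-268 cells (Homo sapiens) for antiproliferative activity, read by MTT assay, with a stated time of 96 h; on this read-out higher numbers stand for weaker inhibition and lower numbers for stronger inhibition:

compound 1, `COc1ccc(N2C(=O)NC3(CSC4=C3C(=O)c3ncccc3C4=O)C2=O)cc1`, gives 650 nM
compound 2, `O=C1C2=C(C(=O)c3ncccc31)C1(CS2)NC(=O)N(c2ccc(Cl)cc2)C1=O`, gives 580 nM
compound 3, `O=C1C2=C(C(=O)c3ncccc31)C1(CS2)NC(=O)N(c2ccc([N+](=O)[O-])cc2)C1=O`, gives 1520 nM

Compound 3 stands at the highest number of the three, that is the weakest inhibition. The step of a 1.1-fold lower number from compound 1 to compound 2 (0.05 log units; within the scatter) shows that methoxy and chloro give numbers that cannot be told apart. The steps of a 2.3-fold higher number from compound 1 to compound 3 (0.37 log units; beyond the scatter) and a 2.6-fold higher number from compound 2 to compound 3 (0.42 log units; beyond the scatter) are both modest but beyond the scatter, so the nitro group goes with a weaker result than either other group.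

Compound 4, `CCN(CC)c1ccc(N2C(=O)NC3(CSC4=C3C(=O)c3ncccc3C4=O)C2=O)cc1`, differs from compound 3 in one place: diethylamino in place of nitro on an aromatic carbon. No measurement of diethylamino in this position exists, so only the two steps that brought nitro in bear on it, and both raised the number modestly. The step in which nitro leaves is therefore expected to run the other way, with compound 4 estimated at a 2.2-fold lower number from compound 3 to compound 4 (0.34 log units; beyond the scatter), back into the range of compound 1 and compound 2. Compound 4 is expected at 700 nM, with a range from 300 nM to 2000 nM.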

Compound 4, half-maximal inhibitory concentration: 960 nM
Compound 4: the middle estimate sits 1.4-fold (0.14 log units) below what was measured; the range from low to high includes it.
By their numbers in this assay, from the lowest: compounds 2, 1, 4 and 3 (each within the scatter of the next, the first and the last beyond it).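

The steps of a 1.6-fold lower number from compound 3 to compound 4 (0.20 log units; within the scatter), a 1.7-fold higher number from compound 2 to compound 4 (0.22 log units; within the scatter) and a 1.5-fold higher number from compound 1 to compound 4 (0.17 log units; within the scatter) all lie within the scatter, so at this position diethylamino cannot be told apart from nitro, chloro or methoxy. This position therefore accepts a group of 5 heavy atoms, with no ring, without a change beyond the scatter. Nitro remains separated from chloro and methoxy, but diethylamino now fills the gap, so the four compounds form one continuous spread rather than two clear groups, and nothing available explains this spread.

From the compounds shown here alone, it remains open how a smaller amine such as dimethylamino, or the simple unsubstituted amine, would compare at this position. A ring-bearing amine such as morpholine or a carboxylic acid there also remains untested by the compounds shown.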